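Substituent change on the shared core: notes toward compound 4

The source may hold more compounds than are shown below. What is called first, only, known or untested is meant among the compounds shown, and "the series" means these compounds.

Measured in an ADME assay on cells for inhibition of cytochrome P450 11B1, mitochondrial (Homo sapiens), read by HPLC, with a stated time of 60 min; a higher number here means a weaker inhibitor, a lower number a stronger inhibitor:
compound 1, `Cc1ncncc1-c1nc2cc(F)c(F)cc2n1C1CC1`, 4160 nM
compound 2, `Fc1cc2nc(-c3cncnc3C3CC3)n(C3CC3)c2cc1F`, > 10000 nM (a limit of the assay, not a number)
compound 3, `N#Cc1ncncc1-c1nc2cc(F)c(F)cc2n1C1CC1`, 4990 nM

Compound 3 and compound 1 give numbers within the scatter of each other, so no order between them can be read; the step of a 1.2-fold higher number from compound 1 to compound 3 (0.08 log units; within the scatter) confirms this. Compound 2 sits at the limit of > 10000 nM in this assay, at which 1 of the 3 values shown sits. The step of an at least 2.4-fold higher number from compound 1 to compound 2 (0.38 log units; beyond the scatter) is the only one beyond the scatter, and the step of an at least 2.0-fold lower number from compound 2 to compound 3 (0.30 log units; that floor lies within the scatter) has a floor that lies within it.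

Compound 4, `Fc1cc2nc(-c3cncnc3C(F)F)n(C3CC3)c2cc1F`, is not yet measured in this assay. The change from compound 3 is difluoromethyl in place of cyano on an aromatic carbon. The steps of a 1.2-fold higher number from compound 1 to compound 3 (0.08 log units; within the scatter) and an at least 2.4-fold higher number from compound 1 to compound 2 (0.38 log units; beyond the scatter) bear on it: cyano and methyl sit together, whereas cyclopropyl pushed the number to the limit. Difluoromethyl enters between those sizes, so a modest rise in this assay is expected, not beyond the scatter with confidence. The expected step is a 1.4-fold higher number from compound 3 to compound 4 (0.15 log units; within the scatter). For compound 4 the estimate is 7000 nM, with a range from 3000 nM to 16000 nM.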

Compound 4, half-maximal inhibitory concentration: 4330 nM
Compound 4: middle estimate off by 1.6-fold (0.21 log units), on the high side, and the stated range covers the measured number.
By their numbers in this assay, from the lowest: compounds 1, 4 and 3 (each within the scatter of the next). At a limit, above all of these: compound 2.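

In this assay, the steps of a 1.2-fold lower number from compound 3 to compound 4 (0.06 log units; within the scatter) and a 1.0-fold higher number from compound 1 to compound 4 (0.02 log units; within the scatter) put difluoromethyl together with cyano and methyl, so no order can be read among these three groups on this aromatic carbon. Cyclopropyl stands apart from them, and the step of an at least 2.3-fold lower number from compound 2 to compound 4 (0.36 log units; beyond the scatter) gives a second comparison beyond the scatter, so the separation of compound 2 no longer rests on compound 1 alone. The value of compound 2 remains a limit of the assay, not a number: the limit of > 10000 nM in this assay, at which 1 of the 4 values shown sits.

On these data alone, whether a methoxy group or an amine on this carbon would stay with methyl, cyano and difluoromethyl or part from them remains open. As far as these compounds go, how far compound 2 lies from the other compounds also stays open.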